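Methyl for Methoxycarbonyl on a Fused Sulfonamide Core

The source may hold more compounds than are shown below. What is called first, only, known or untested is meant among the compounds shown, and "the series" means these compounds.

Measured compounds:
Compound 1, `COC(=O)c1cc2c(cc1Cl)SC(N(N(C)C)S(=O)(=O)c1ccc(Cl)cc1)=NS2(=O)=O`: 18700 nM
Compound 2, `CCOC(=O)c1cc2c(cc1Cl)SC(N(c1ccccc1)S(=O)(=O)c1ccc(Cl)cc1)=NS2(=O)=O`: 14800 nM
Compound 3, `O=C(Oc1cccc2cccnc12)c1cc2c(cc1Cl)SC(N(c1ccc(F)cc1)S(=O)(=O)c1ccc(Cl)cc1)=NS2(=O)=O`: 9300 nM

Of the compounds shown here, three sharing one fused core have been tested in a functional assay on DAN-G cells (Homo sapiens) for cytotoxicity, with a stated time of 96 h; a lower number here means a stronger inhibitor of growth, a higher number a weaker inhibitor of growth. Compound 1 gives 18700 nM, compound 2 gives 14800 nM and compound 3 gives 9300 nM. Compound 1 has the highest of the three numbers, yet its gaps to compound 2 and to compound 3 both lie within the usual scatter, so the three cannot be separated on these data.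

The next compound, compound 4, `Cc1cc2c(cc1Cl)SC(N(N(C)C)S(=O)(=O)c1ccc(Cl)cc1)=NS2(=O)=O`, has not yet been measured in this assay. It differs from compound 1 in one place: methyl in place of methoxycarbonyl on an aromatic carbon. Within the data shown here, no pair among the measured compounds differs in a single place, so there is no measured step to lean on for this change.

Given that, the step from compound 1 to compound 4 in this assay is expected to be small and within the scatter, with no clear direction: a 1.2-fold higher number from compound 1 to compound 4 (0.07 log units; within the scatter). Compound 4 is therefore estimated to give 22000 nM, with a range from 7000 nM to 70000 nM.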

Compound 4, concentration for 50% growth inhibition: 23500 nM
The estimate for compound 4 lay 1.1-fold (0.03 log units) below the measured number; measured number inside the range.
By their numbers in this assay, from the lowest: compounds 3, 2, 1 and 4 (each within the scatter of the next, the first and the last beyond it).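

Among these compounds, the replacement of methoxycarbonyl by methyl on the aromatic carbon ortho to a chloro group is the first single-place comparison in this set, and in this assay it amounts to a 1.3-fold higher number from compound 1 to compound 4 (0.10 log units; within the scatter) on the core of compound 1. At this position, then, removing the methoxycarbonyl with its carbonyl and its 2 hydrogen-bond acceptors leaves the growth-inhibition number within the scatter, so this group is not shown to matter for the number in this one pair. Nothing given here offers an explanation for this result.

On these data alone, it remains open whether a carboxylic acid, a primary amide or an amine at this position would also stay within the scatter. As far as these compounds go, it is also open whether methyl for methoxycarbonyl would give a similar step on the core of compound 2 or compound 3.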